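Urea Series in MNK45 Cells: Estimating a Methylbenzyl Analog

This account rests on a few compounds, and the source may have more. Where it says the series, first, only, none or still open, it means among the compounds named here.

Compound 1 `Cc1ccc(NC(=S)NC(=O)c2ccc(OCc3ccccc3F)cc2)cc1-c1nc2ccccc2[nH]1` gives 2420 nM in a functional assay on MNK45 cells (Homo sapiens) for inhibition, read by MTT assay, with a stated time of 48 h; a higher number here means a weaker inhibitor, a lower number a stronger inhibitor.
Compound 2 `Cc1ccc(NC(=O)NC(=O)c2ccc(OCc3cccc(Cl)c3)cc2)cc1-c1nc2ccccc2[nH]1` gives 28000 nM in this assay.

Of the compounds shown here, two have been measured so far, and they differ from each other in more than one place, so no single step between them can be read. Compound 2 stands at the higher of the two numbers; its nearest neighbour is compound 1, whose number is lower, a gap that lies well beyond the usual scatter of this assay.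

Compound 3 `Cc1ccc(COc2ccc(C(=O)NC(=O)Nc3ccc(C)c(-c4nc5ccccc5[nH]4)c3)cc2)cc1` has not yet been measured. It differs from compound 2 in one place only: 4-methylphenyl in place of 3-chlorophenyl on a saturated chain carbon bound to an oxygen on an aromatic ring. Among the compounds with values here, no measured pair shows this kind of exchange, so there is no step on record to guide the size of the expected effect. With nothing to point either way, the author expects the step of a 1.3-fold lower number from compound 2 to compound 3 (0.10 log units; within the scatter) to be modest and, most likely, within or close to the scatter of this assay. On that basis compound 3 is estimated at 22000 nM, with a range from 6000 nM to 70000 nM.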

Compound 3, half-maximal inhibitory concentration: 6360 nM
Compound 3: middle estimate off by 3.5-fold (0.54 log units), on the high side; low and high end bracket the measured number.
By their numbers in this assay, from the lowest: compound 1; then compound 3; then compound 2.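

The exchange of 3-chlorobenzyl for 4-methylbenzyl on the ether oxygen gives a 4.4-fold lower number from compound 2 to compound 3 (0.64 log units; beyond the scatter) in this assay, so this position affects the result, and a swap between two groups with the same count of heavy atoms is enough to move the number beyond the scatter. Within the data shown here, compound 1 differs from compound 2 and from compound 3 in more than one place, so no step involving it can be read, and this exchange remains the only one on record for the series. No available measurement bears on why the number moves with this change.

The exchange removes the chlorine, adds the methyl and changes where the substituent sits on the phenyl ring, and the compounds shown do not separate these contributions to the step. They also leave open how the series would respond to an amine, a carboxylic acid or a longer chain at this same place on the saturated chain carbon bound to the oxygen on the aromatic ring.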